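A few compounds are considered here, and "the series" means these few. Any claim that something is new, unique, unknown or untested is made for them only; others in the source may bear on it.

Compound 1 `CC(C)(O)C#Cc1cc(C(O)(C(F)(F)F)C(F)(F)F)cnc1N1CCN(S(=O)(=O)c2ccc(N)nc2)CC1` is the starting point. In an ADME assay (liver) for metabolic stability, with Liver microsome (Rattus norvegicus) as the target, using microsomes and NADPH, with a stated time of 30 min, tested at 1 uM (on this read-out higher numbers stand for fast clearance and lower numbers for slow clearance), compound 1 gives 16 mL.min-1.g-1, the lowest of the three numbers measured here. Two close relatives are already known. Compound 2 `COc1ccc(-c2cc(C(O)(C(F)(F)F)C(F)(F)F)cnc2N2CCN(S(=O)(=O)c3ccc(N)nc3)CC2)cn1` gives 265 mL.min-1.g-1 in this assay, and compound 3 `COc1cncc(-c2cc(C(O)(C(F)(F)F)C(F)(F)F)cnc2N2CCN(S(=O)(=O)c3ccc(N)nc3)CC2)c1` gives 58 mL.min-1.g-1. Both steps from the starting point go the same way: a 17-fold higher number from compound 1 to compound 2 (1.22 log units; beyond the scatter), and a 3.6-fold higher number from compound 1 to compound 3 (0.56 log units; beyond the scatter); between the two relatives the move is a 4.6-fold lower number from compound 2 to compound 3 (0.66 log units; beyond the scatter).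

Compound 4 `Nc1ccc(S(=O)(=O)N2CCN(c3ncc(C(O)(C(F)(F)F)C(F)(F)F)cc3-c3ccc4scnc4c3)CC2)cn1` is not yet measured. Its change from compound 1 is 1,3-benzothiazol-5-yl in place of 3-hydroxy-3-methylbut-1-yn-1-yl on an aromatic carbon. The two measured steps both swap the same 3-hydroxy-3-methylbut-1-yn-1-yl for a ring-bearing group at the same place, and both raise the clearance number beyond the scatter, by a modest to large amount. Compound 4 makes a swap of the same kind, so a step upward is expected, of roughly the size seen so far: a 6.3-fold higher number from compound 1 to compound 4 (0.80 log units; beyond the scatter). Compound 4 is therefore estimated at 100 mL.min-1.g-1, with a range of 40 mL.min-1.g-1 to 250 mL.min-1.g-1 in this assay.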

Compound 4, intrinsic clearance in microsomes: 147 mL.min-1.g-1
Compound 4: the middle estimate sits 1.5-fold (0.17 log units) below what was measured, within the range that was stated.
By their numbers in this assay, from the lowest: compound 1; then compound 3; then compounds 4 and 2 (each within the scatter of the next).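

Changing to a fused two-ring group, 1,3-benzothiazol-5-yl, also raises the number in this assay, with a 9.2-fold higher number from compound 1 to compound 4 (0.96 log units; beyond the scatter), so all three ring-bearing groups shown stand above the 3-hydroxy-3-methylbut-1-yn-1-yl group of compound 1. The ring groups do not behave alike, as there is a 2.5-fold higher number from compound 3 to compound 4 (0.40 log units; beyond the scatter), whereas a 1.8-fold lower number from compound 2 to compound 4 (0.26 log units; within the scatter) stays within the scatter, which leaves compound 3 as the only one of the three set apart from the others. Nothing available here explains these differences.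

The compounds shown leave open whether the low number of compound 1 depends on its triple bond or on its hydroxyl group. They also leave open whether a saturated amine such as morpholine, or a simple alkyl chain, at this place would stay close to compound 1.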